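The source may hold more compounds than are shown below. What is called first, only, known or untested is meant among the compounds shown, and "the series" means these compounds.

In a functional assay on HepG2 cells (Homo sapiens) for antiproliferative activity, read by MTT assay, with a stated time of 72 h (on this read-out higher numbers stand for weaker inhibition and lower numbers for stronger inhibition), compound 3 `O=C(N/N=C/c1ccccc1)Nc1ccc(Oc2ccnc3[nH]ccc23)cc1` gives 750 nM. Compound 1 `O=C(N/N=C/c1ccccc1)Nc1ccc(Oc2ccnc3[nH]ccc23)c(F)c1` carries a fluoro group where compound 3 has hydrogen. Compound 1 gives 640 nM. That change is a 1.2-fold higher number from compound 1 to compound 3 (0.07 log units; within the scatter), so the two stand level. Compound 2 `O=C(N/N=C/c1cccc([N+](=O)[O-])c1)Nc1ccc(Oc2ccnc3[nH]ccc23)c(F)c1` gives 5180 nM, a clearly higher number than either.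

Compound 4 `O=C(N/N=C/c1cccc(Cl)c1Cl)Nc1ccc(Oc2ccnc3[nH]ccc23)cc1` is compound 3 changed at one place: 2,3-dichlorophenyl in place of phenyl on a carbon with a double bond to nitrogen. In words, 2,3-dichlorophenyl stands in place of phenyl on a carbon with a double bond to nitrogen.

For the measured compounds named here, two measured steps bear on this change. The only one that adds a substituent to that phenyl is nitro in place of hydrogen, an 8.1-fold higher number from compound 1 to compound 2 (0.91 log units; beyond the scatter). It is a single case, and it was measured with the fluoro group present. The fluoro change itself, a 1.2-fold higher number from compound 1 to compound 3 (0.07 log units; within the scatter), gives no sign that this matters. Going by the values given here, no compound with chlorine has been measured, so the nitro step shows only that substitution on this phenyl can raise the number. A smaller rise in the same direction is therefore expected, with wide uncertainty. The expected change is a 2.0-fold higher number from compound 3 to compound 4 (0.30 log units; within the scatter). For compound 4 the estimated value is 1500 nM, with an expected range from 350 nM to 6000 nM.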

Compound 4, half-maximal inhibitory concentration: "not active" (no number reported)
Compound 4: no number reported, so the estimate cannot be set against anything.
By their numbers in this assay, from the lowest: compounds 1 and 3 (each within the scatter of the next); then compound 2.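

In this assay, for the compounds shown here, compound 4 is reported only as "not active", with no number, so no step from compound 3 to compound 4 can be read. The compounds shown leave open how far 2,3-dichlorophenyl in place of phenyl moves the number. Nothing available accounts for this result.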